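A few compounds are considered here, and "the series" means these few. Any claim that something is new, unique, unknown or untested is made for them only; others in the source may bear on it.

Of the compounds shown here, three built on one shared core have been measured in a functional assay on EKVX cells (Homo sapiens) for inhibition, read by sulforhodamine B assay, with a stated time of 48 h; on this read-out higher numbers stand for weaker inhibition of growth and lower numbers for stronger inhibition of growth. Compound 1 `Nc1cc(N)c2nc(-c3ccccc3)c(NCc3ccc(Cl)c(Cl)c3)nc2c1` gives 38900 nM. Compound 2 `COc1ccc(CNc2nc3cc(N)cc(N)c3nc2-c2ccccc2)cc1OC` gives 30200 nM in this assay, and the step from compound 1 to compound 2 is a 1.3-fold lower number from compound 1 to compound 2 (0.11 log units; within the scatter). Compound 3 `Nc1cc(N)c2nc(-c3ccccc3)c(NCc3ccc(F)cc3)nc2c1` gives 4070 nM, the lowest of the three numbers, with compound 2 nearest and compound 1 furthest, both beyond the scatter. The two steps leading to compound 3 are a 9.6-fold lower number from compound 1 to compound 3 (0.98 log units; beyond the scatter) and a 7.4-fold lower number from compound 2 to compound 3 (0.87 log units; beyond the scatter).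

Compound 4 `COc1ccc(CNc2nc3cc(N)cc(N)c3nc2-c2ccccc2)cc1` differs from compound 3 by methoxy in place of fluoro on an aromatic carbon. Going by the values given here, no measured pair swaps fluoro for methoxy on its own at this place. The step that bears most on it is a 7.4-fold lower number from compound 2 to compound 3 (0.87 log units; beyond the scatter), where a 3,4-dimethoxyphenyl gave way to the 4-fluorophenyl of compound 3; some share of that modest step may rest on the methoxy at the same carbon, so the return of a single methoxy is expected to raise the number somewhat, though probably by less than the whole of that step. Compound 4 is therefore expected to give about 9000 nM in this assay, with a likely range from 3000 nM to 30000 nM. This estimate amounts to an expected step of a 2.2-fold higher number from compound 3 to compound 4 (0.34 log units; beyond the scatter).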

Compound 4, concentration for total growth inhibition: 28200 nM
For compound 4 the middle estimate is 3.1-fold (0.50 log units) below the measured one; the measured number falls inside the stated range.
By their numbers in this assay, from the lowest: compound 3; then compounds 4, 2 and 1 (each within the scatter of the next).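

In this assay, going by these compounds alone, the earlier steps to compound 3 each changed more than one substituent on the phenyl ring, whereas this one isolates a single exchange on the aromatic carbon para to a large group, and methoxy in place of fluoro there gives a 6.9-fold higher number from compound 3 to compound 4 (0.84 log units; beyond the scatter). The further methoxy of compound 2 makes no readable difference, with a 1.1-fold lower number from compound 2 to compound 4 (0.03 log units; within the scatter), and the 4-methoxyphenyl and 3,4-dichlorophenyl groups are not separated either, with a 1.4-fold lower number from compound 1 to compound 4 (0.14 log units; within the scatter), so among these four compounds only the 4-fluorophenyl of compound 3 stands apart from the rest, and the single para methoxy is enough to remove that advantage. Nothing available here explains why fluoro and methoxy differ in this way at this carbon.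

As far as these compounds go, it remains open whether the low number of compound 3 is particular to fluoro or would also be seen with hydrogen, chloro, methyl or an amine at the same carbon. From the compounds shown here alone, it is also open whether a fluoro at this carbon would keep its advantage with a second substituent on the ring, such as a further fluoro or a chloro.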